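The compounds below may be only part of what the source reports. "The series", "measured", "known", "first", "only" and "open" are said of these compounds alone.

Measured compounds:
Compound 1 `ClCc1ccc(Cn2cnc3c(Cl)ncnc32)cc1` gives 66100 nM in a functional assay on HOP-92 cells (Homo sapiens) for cytotoxicity, read by sulforhodamine B assay, with a stated time of 48 h; a lower number here means a stronger inhibitor of growth, a higher number a weaker inhibitor of growth.
Compound 2 `ClCc1ccccc1Cn1cnc2c(Cl)nc(Cl)nc21` gives 970 nM in this assay.

Compound 2 has the lower of the two numbers, and its nearest neighbour, compound 1, lies far above it, beyond the scatter. Compound 3 `ClCc1ccccc1Cn1cnc2c(Cl)ncnc21` differs from compound 2 by hydrogen in place of chloro on an aromatic carbon. Going by the values given here, no step between measured compounds matches this change. He expects the number to rise, by more than the scatter, so the step of an 8.2-fold higher number from compound 2 to compound 3 (0.92 log units; beyond the scatter) is an estimate only. For compound 3 he therefore expects about 8000 nM, within 1500 nM to 40000 nM.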

Compound 3, concentration for total growth inhibition: 4260 nM
Compound 3: the middle estimate sits 1.9-fold (0.27 log units) above what was measured; measured number inside the range.
By their numbers in this assay, from the lowest: compound 2; then compound 3; then compound 1.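

In this assay, the chloro group on the aromatic carbon between two ring nitrogen atoms proves to matter: replacing it with hydrogen gives a step beyond the scatter (a 4.4-fold higher number from compound 2 to compound 3 (0.64 log units; beyond the scatter)). Going by these compounds alone, this is the first direct comparison at this position, and it favours chloro over hydrogen in this single pair. No available evidence accounts for the step.

The compounds shown leave open how an amine or a methoxy group at this position would compare with chloro. They also leave open whether the same change would have a similar effect with the chloromethyl group elsewhere on the benzene ring.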